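The source may hold more compounds than are shown below. What is called first, only, known or untested is meant among the compounds shown, and "the series" means these compounds.

Measured so far in a functional assay on NCI-H460 cells (Homo sapiens) for inhibition, read by MTT assay, with a stated time of 72 h; a higher number here means a weaker inhibitor, a lower number a stronger inhibitor:

compound 1, `CC(=O)Nc1cccc(C(=O)/C=C2/C(=O)Nc3ccccc32)c1`, with 12300 nM
compound 2, `O=C1Nc2ccccc2/C1=C\C(=O)c1ccccc1F`, with 8500 nM

Compound 1 stands with the higher of the two numbers, but the gap to compound 2 lies within the usual scatter of repeated measurements, so the two cannot be put in order on these data. Within the data shown here, the pair does not share a single change in one place, so no measured step is available to guide the next estimate.

Compound 3, `O=C1Nc2ccccc2/C1=C\C(=O)c1cccc(Cl)c1`, has not yet been measured in this assay. It differs from compound 1 as follows: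

chloro in place of acetamido on an aromatic carbon

Among the measured compounds shown here, nothing among the measured compounds isolates this change, so the expected effect can rest only on the closeness of the two values seen. The account therefore expects a small step, if any, in the direction of a lower number, and most likely one that stays within the scatter.

The estimated step of a 1.8-fold lower number from compound 1 to compound 3 (0.24 log units; within the scatter) is taken to be modest. Compound 3 is expected to give about 7000 nM in this assay, within a range from 2500 nM to 20000 nM.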

Compound 3, half-maximal inhibitory concentration: 9800 nM
Beside the measured number, compound 3's estimate is 1.4-fold (0.15 log units) below it, within the range that was stated.
By their numbers in this assay, from the lowest: compounds 2, 3 and 1 (each within the scatter of the next).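

In this assay, the exchange of acetamido for chloro on an aromatic carbon, meta to a large group, now has a measured size: a 1.3-fold lower number from compound 1 to compound 3 (0.10 log units; within the scatter). The group that leaves has 4 heavy atoms, with 1 hydrogen-bond donor and 1 hydrogen-bond acceptor, and the one that enters has a single chlorine atom with neither, yet compound 1 and compound 3 cannot be told apart on these numbers. For this one pair, then, a large difference in the group at this position goes with no difference that the assay can resolve, which is more than the earlier values could say about any single position. No measurement at hand accounts for this result.

On these data alone, this reading rests on a single pair, so it remains open whether the number would stay in the same range with an amine, a carboxylic acid or a longer chain on the same aromatic carbon. As far as these compounds go, it is also open whether chloro would give a similar number at another carbon of that ring, or whether any group at this position would produce a step beyond the scatter.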